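A few compounds are considered here, and "the series" means these few. Any claim that something is new, unique, unknown or untested is made for them only; others in the source may bear on it.

Compound 1 `CCCCCc1ccc(CCc2cc3cn([C@H]4C[C@H](O)[C@@H](CO)O4)c(=O)nc3o2)cc1`: in an ADME assay on HEL cells (Homo sapiens) for cytotoxicity, with a stated time of 3 days (a lower number here means that less compound is tolerated, a higher number that more compound is tolerated), compound 1 gives > 470000 nM, which is a limit of the measurement and not a number.
Compound 2 `CCCc1ccc(CCc2cc3cn([C@H]4C[C@H](O)[C@@H](CO)O4)c(=O)nc3o2)cc1`: in this assay compound 2 gives > 130000 nM, again a limit.
Compound 3 `CCCCc1ccc(-c2cc3cn([C@H]4C[C@H](O)[C@@H](CO)O4)c(=O)nc3o2)nc1`: in this assay compound 3 gives > 50000 nM, also a limit.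

From compound 2 to compound 1 the change is ethyl in place of hydrogen on a saturated chain carbon, three bonds along the chain from an aromatic carbon. The step that the two limits leave unreadable from compound 2 to compound 1 cannot be read: both of its ends are limits.

Compound 4 `CCCCCCc1ccc(-c2cc3cn([C@H]4C[C@H](O)[C@@H](CO)O4)c(=O)nc3o2)nc1` is not yet measured. It differs from compound 3 by ethyl in place of hydrogen on a saturated chain carbon, four bonds along the chain from an aromatic carbon. Among the compounds with values here, this is the same kind of change as the one from compound 2 to compound 1, though the place differs: three bonds along the chain from an aromatic carbon there, four bonds along the chain from an aromatic carbon here. The difference between the cores of compound 2 and compound 3 is not broken down here.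

For compound 4 a step that the limit leaves unreadable from compound 3 to compound 4 in this assay is expected, with a limit rather than a number the likelier outcome. That expectation rests on the step that the two limits leave unreadable from compound 2 to compound 1, whose size is unreadable, and on compound 3, whose value > 50000 nM is itself a limit. Compound 4 is therefore estimated at about 60000 nM.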

Compound 4, half-maximal cytotoxic concentration: > 50000 nM
Compound 4 ended at the assay's limit (the forecaster's own chance of this, stated with the estimate: 70%); the middle value is on the limit's open side.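

The step from compound 3 to compound 4 cannot be read in this assay, as both compounds give only a limit and not a number. The compounds shown leave open whether ethyl in place of hydrogen changes cytotoxicity at all.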